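The compounds below may be only part of what the source reports. "The series", "measured", "known", "first", "only" and "open" are said of these compounds alone.

The measured compounds:
compound 1 `COc1cc2c(Oc3c(F)cc(NC(=O)NN4C(=O)CSC4c4c(F)cccc4F)cc3F)ccnc2cc1OCCCN1CCC(C)CC1`, which in a functional assay on HT-29 cells (Homo sapiens) for antiproliferative activity, read by MTT assay, with a stated time of 72 h (on this read-out lower numbers stand for stronger inhibition and higher numbers for weaker inhibition), gives 220 nM
compound 2 `COc1cc2c(Oc3c(F)cc(NC(=O)NN4C(=O)CSC4c4c(F)cccc4F)cc3F)ccnc2cc1OCCCN1C[C@H]2CCCC[C@H]2C1`, which in this assay gives 470 nM
compound 3 `COc1cc2c(Oc3c(F)cc(NC(=O)NN4C(=O)CCSC4c4c(F)cccc4F)cc3F)ccnc2cc1OCCCN1CCC(C)CC1`, which in this assay gives 410 nM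

Compound 1 and compound 2 share a core and differ in one place only: a group of 9 heavy atoms (8 carbon, 1 nitrogen; one five-membered non-aromatic ring with 1 hetero atom, one six-membered non-aromatic ring of carbon only) in place of a group of 7 heavy atoms (6 carbon, 1 nitrogen; one six-membered non-aromatic ring with 1 hetero atom), on a saturated chain carbon, three bonds along the chain from an oxygen on an aromatic ring. On that exchange the read-out moved by a 2.1-fold higher number from compound 1 to compound 2 (0.33 log units; beyond the scatter). Compound 3 carries a core that is not the same as that of compound 1; the difference between the two cores is not broken down here. In this assay compound 3 and compound 2 lie within the usual scatter of each other, and compound 3 also lies within that scatter of compound 1.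

Compound 4 `COc1cc2c(Oc3c(F)cc(NC(=O)NN4C(=O)CCSC4c4c(F)cccc4F)cc3F)ccnc2cc1OCCCN1C[C@H]2CCCC[C@H]2C1` has not yet been measured in this assay. It stands to compound 3 as compound 2 stands to compound 1: a group of 9 heavy atoms (8 carbon, 1 nitrogen; one five-membered non-aromatic ring with 1 hetero atom, one six-membered non-aromatic ring of carbon only) in place of a group of 7 heavy atoms (6 carbon, 1 nitrogen; one six-membered non-aromatic ring with 1 hetero atom), on a saturated chain carbon, three bonds along the chain from an oxygen on an aromatic ring. The place of the exchange reads the same, word for word, in both pairs, so this is the same change on a different core. Whether the second core answers the change as the first one did is not shown by any measured pair, so the expectation rests on the single earlier step alone. Because compound 3 gives 410 nM and the earlier exchange made a 2.1-fold higher number from compound 1 to compound 2 (0.33 log units; beyond the scatter), the step is expected to be a 2.1-fold higher number from compound 3 to compound 4 (0.32 log units; beyond the scatter). Compound 4 is therefore estimated to give about 850 nM in this assay, with a plausible range from 430 nM to 1700 nM.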

Compound 4, half-maximal inhibitory concentration: 790 nM
For compound 4 the middle estimate is 1.1-fold (0.03 log units) above the measured one, within the range that was stated.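

In this assay, putting the group with a five-membered and a six-membered ring in place of 4-methylpiperidin-1-yl, on the same saturated chain carbon, gave a 1.9-fold higher number from compound 3 to compound 4 (0.28 log units; within the scatter). Set beside the earlier exchange, this step runs in the same direction and is of much the same size, so the two cores show no measurable difference in how they answer the change: the same change on two cores in this assay, a 2.1-fold higher number (0.33 log units; beyond the scatter) from compound 1 to compound 2 and a 1.9-fold higher number (0.28 log units; within the scatter) from compound 3 to compound 4, 1.1-fold (0.04 log units) apart, within the scatter of two such steps This is agreement between only two pairs, however, and the second step does not by itself stand clear of the scatter, so the result supports carrying the change from one core to the other without establishing a rule for the series or explaining why the numbers move as they do.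

The compounds shown leave open whether the same exchange would read alike with other amines on the chain, such as morpholine or 4-methylpiperazine, or on a longer chain than the one carried here. They also leave open how the change would behave on a core bearing another aryl group, such as an unsubstituted phenyl, in place of the difluorophenyl ring.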